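A few compounds are considered here, and "the series" means these few. Any claim that something is new, unique, unknown or untested is made for them only; others in the source may bear on it.

Going by the values given here, compound 1 `O=C(Nc1ccc(C(F)(F)F)cc1)c1cc(F)ccc1O` is one of three compounds measured in a functional assay on HL-60 cells (Homo sapiens) for cytotoxicity, read by luminescence and CellTiter-Glo, with a stated time of 3 days (a higher number here means a weaker inhibitor, a lower number a stronger inhibitor), where compound 1 gives 490 nM. Compound 2 `O=C(Nc1ccc(C(F)(F)F)cc1)c1cc(Br)ccc1O` carries the change (bromo in place of fluoro on an aromatic carbon), and in this assay compound 2 gives 580 nM; the step of a 1.2-fold higher number from compound 1 to compound 2 (0.07 log units; within the scatter) was small. Compound 3 `N#Cc1ccc(NC(=O)c2ccc(F)cc2O)cc1` shares the same kind of scaffold but is built on a different core; the difference between the two cores is not broken down here. In this assay compound 3 gives 1380 nM, the highest number of the three and beyond the scatter from both compound 1 and compound 2.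

Compound 4 `N#Cc1ccc(NC(=O)c2ccc(Br)cc2O)cc1` has not been measured. Relative to compound 3 it carries bromo in place of fluoro on an aromatic carbon. Among the compounds with values here, this is the same kind of change as the one from compound 1 to compound 2, though the surroundings differ: here the bromo sits meta to a hydroxy group and para to a large group, whereas in compound 2 it sits meta to a large group and para to a hydroxy group. Because the step of a 1.2-fold higher number from compound 1 to compound 2 (0.07 log units; within the scatter) stayed within the scatter, compound 4 is expected to show a similarly small step a 1.2-fold higher number from compound 3 to compound 4 (0.06 log units; within the scatter) in this assay. Compound 4 is therefore estimated at 1600 nM, with a likely range from 800 nM to 3300 nM.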

Compound 4, half-maximal inhibitory concentration: 1210 nM
Estimate against measurement, compound 4: 1.3-fold (0.12 log units) above; the range from low to high includes it.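

In this assay, putting bromo in place of fluoro on the core of compound 3 gave a 1.1-fold lower number from compound 3 to compound 4 (0.06 log units; within the scatter), a step within the scatter, as on the core of compound 1. Set side by side, the two steps do not differ: the same change on two cores in this assay, a 1.2-fold higher number (0.07 log units; within the scatter) from compound 1 to compound 2 and a 1.1-fold lower number (0.06 log units; within the scatter) from compound 3 to compound 4, 1.3-fold (0.13 log units) apart, within the scatter of two such steps. This shows that, in these two pairs, the exchange of fluoro for bromo carried from one core to the other with no change that this read-out can resolve, but it rests on two pairs and a single assay, and it does not show that the two halogens are interchangeable on any other core or that either one contributes to the activity.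

The compounds shown leave open whether hydrogen, or a group of another kind such as an amine or a carboxylic acid, would be met as flatly in this place as fluoro and bromo are. They also leave open whether the same holds on a core that carries neither the trifluoromethyl nor the nitrile.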